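The source may hold more compounds than are shown below. What is called first, only, known or untested is meant among the compounds shown, and "the series" means these compounds.

The measured compounds are:
compound 1, `O=C(CSc1ncccn1)Nc1ccc2nc(NC(=O)c3ccc(C(F)(F)F)cc3)sc2c1`, 28100 nM
compound 2, `Cc1cc(C)cc(C(=O)Nc2nc3ccc(NC(=O)CSc4cccc(O)c4)cc3s2)c1`, 2820 nM
compound 3, `CCn1c(CNc2ccc(OC)cc2)nnc1SCC(=O)Nc1ccc(Cl)cc1`, 63500 nM

All three were tested in a functional assay on U2OS cells (Homo sapiens) for antiproliferative activity, read by MTT assay, with a stated time of 72 h; on this read-out lower numbers stand for stronger inhibition and higher numbers for weaker inhibition. Among these three numbers compound 1 stands second highest: compound 3 gives a higher number, beyond the scatter, and compound 2 gives a lower number and lies furthest away. Compound 4 has the structure `O=C(CSc1ccc(Cl)cc1)Nc1ccc2nc(NC(=O)c3ccc(C(F)(F)F)cc3)sc2c1` and has not yet been measured. It keeps the whole core of compound 1 and differs in one place: 4-chlorophenyl in place of pyrimidin-2-yl on a sulfur. Within the data shown here, no pair of measured compounds shows this same change, so the size of the step can only be guessed. Compound 2, whose sulfur also carries a six-membered aromatic ring of carbon only, gives the lowest number of the three, 2820 nM, but it differs from compound 1 elsewhere as well, so it offers a hint and no more. A modest step towards a lower number is expected, a 2.8-fold lower number from compound 1 to compound 4 (0.45 log units; beyond the scatter). Compound 4 is therefore estimated at 10000 nM, with a range from 2500 nM to 40000 nM.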

Compound 4, half-maximal inhibitory concentration: 2890 nM
The estimate for compound 4 lay 3.5-fold (0.54 log units) above the measured number; the range from low to high includes it.
By their numbers in this assay, from the lowest: compounds 2 and 4 (each within the scatter of the next); then compound 1; then compound 3.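

In this assay, placing 4-chlorophenyl instead of pyrimidin-2-yl on the sulfur gives a 9.7-fold lower number from compound 1 to compound 4 (0.99 log units; beyond the scatter). Among these compounds, this is the first direct reading of this position: with the rest of compound 1 held fixed, changing the group on the sulfur alone moves the number clearly, so the position is not indifferent to what it carries. No measurement at hand explains the step, and the change swaps hetero atoms for ring carbons and adds a chlorine at once, so which part of it matters stays unknown.

Plain phenyl or 4-fluorophenyl on the sulfur would help to separate the role of the chlorine from that of the carbon-only ring. Also open, as far as these compounds go, is how a carboxylic acid on that ring, or a longer chain in place of the ring, would read in this assay.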